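This account rests on a few compounds, and the source may have more. Where it says the series, first, only, none or still open, it means among the compounds named here.

Measured in a functional assay on MCF7 cells (Homo sapiens) for cytotoxicity, read by MTT assay, with a stated time of 48 h; a lower number here means a stronger inhibitor of growth, a higher number a weaker inhibitor of growth:
- Compound 1 `FC(F)(F)c1nc2cc(Cl)c(Cl)cc2n1CC1CC1`: 60200 nM
- Compound 2 `FC(F)(F)c1nc2cc(Cl)c(Cl)cc2n1Cc1ccccc1`: 8700 nM

Compound 2 holds the lower of the two numbers. Compound 3 `FC(F)(F)c1ccc(Cn2c(C(F)(F)F)nc3cc(Cl)c(Cl)cc32)cc1` differs from compound 2 by one change: trifluoromethyl in place of hydrogen on an aromatic carbon. Within the data shown here, the only measured step, a 6.9-fold lower number from compound 1 to compound 2 (0.84 log units; beyond the scatter), lies at a different place, so it bears on this change only loosely. Among the measured compounds shown here, no measured step covers substitution on the aromatic ring. A small step toward a lower number in this assay is therefore expected, though it may stay within the scatter. The expected step is a 1.6-fold lower number from compound 2 to compound 3 (0.20 log units; within the scatter). For compound 3 the estimated value is 5500 nM, with an expected range of 1800 nM to 16000 nM.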

Compound 3, concentration for 50% growth inhibition: 17000 nM
Beside the measured number, compound 3's estimate is 3.1-fold (0.49 log units) below it; the whole stated range lies below it.
By their numbers in this assay, from the lowest: compounds 2 and 3 (each within the scatter of the next); then compound 1.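

In this assay, trifluoromethyl in place of hydrogen on the aromatic carbon para to a large group gives a 2.0-fold higher number from compound 2 to compound 3 (0.29 log units; within the scatter), so this change does not separate the two compounds. Among these compounds, this is the first measured change on the aromatic ring, and the position tolerates trifluoromethyl without a shift beyond the scatter. No available measurement explains this result. The compounds shown leave open whether a methoxy group, an amine or a carboxylic acid on this carbon would move the number, and whether trifluoromethyl would behave alike on other carbons of the ring.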